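The source may report more compounds than this note shows. Statements on the series, on what has been measured and on what is new or still open speak of the compounds shown alone.

Three analogues sharing one core have been tested in a functional assay on BGC-823 cells (Homo sapiens) for antiproliferative activity, read by MTT assay, with a stated time of 48 h; a lower number here means a stronger inhibitor, a higher number a weaker inhibitor. Compound 1 `S=c1oc(-c2ccc3c(c2)OCCO3)nn1CN1CCN(c2cccc(Cl)c2Cl)CC1` gives 22600 nM. For compound 2 `S=c1oc(-c2ccc3c(c2)OCCO3)nn1CN1CCN(c2cccc(Cl)c2)CC1` the result is a limit of the assay, > 50000 nM. For compound 3 `S=c1oc(-c2ccc3c(c2)OCCO3)nn1CN1CCN(c2ccccc2)CC1` the result is likewise a limit, > 50000 nM. Compound 3 thus stands at the weak end of what has been seen, since it sits at the limit of > 50000 nM in this assay, at which 2 of the 3 values shown sit, and only compound 1 returns a number. The step of an at least 2.2-fold higher number from compound 1 to compound 3 (0.34 log units; beyond the scatter) is at least modest, as is an at least 2.2-fold higher number from compound 1 to compound 2 (0.34 log units; beyond the scatter), while a step that the two limits leave unreadable from compound 2 to compound 3 cannot be sized from two limits. Compound 4 `COc1cccc(N2CCN(Cn3nc(-c4ccc5c(c4)OCCO5)oc3=S)CC2)c1` differs from compound 3 by methoxy in place of hydrogen on an aromatic carbon. Within the data shown here, none of the measured steps involves a methoxy group; all concern chloro, and they show only that removing chloro raises the number or leaves it at the limit. The expectation for a number no higher from compound 3 to compound 4 (the limit leaves the size open) is therefore no step beyond the scatter, with compound 4 most likely remaining at the limit. Compound 4 is estimated at 50000 nM, within a range of 15000 nM to 100000 nM.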

Compound 4, half-maximal inhibitory concentration: > 50000 nM
Compound 4 ended at the assay's limit (the forecaster's own chance of this, stated with the estimate: 65%); the middle value lies on the limit itself.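

In this assay compound 4 gives > 50000 nM, which is a limit of the assay, so methoxy on this aromatic carbon, meta to a large group, yields no readable number. Set against the 2,3-dichlorophenyl group of compound 1, the change to 3-methoxyphenyl gives an at least 2.2-fold higher number from compound 1 to compound 4 (0.34 log units; beyond the scatter), which is at least modest and extends that drop to a group that holds no chloro. The steps linking compound 4 to compound 2 and compound 3 cannot be read, and these three compounds now stand together at a single limit: the limit of > 50000 nM in this assay, at which 3 of the 4 values shown sit.

As far as these compounds go, it remains open how far compound 2, compound 3 and compound 4 truly differ from one another. From the compounds shown here alone, it is also open whether a hydroxyl, an amine or a carboxylic acid at this place, or methoxy added to the 2,3-dichlorophenyl group of compound 1, would return a readable number.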